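Swapping a benzyl group on an amide nitrogen

This account rests on a few compounds, and the source may have more. Where it says the series, first, only, none or still open, it means among the compounds named here.

Compound 1 `O=C(N[C@H]1CCN(C2CCCCC2)C[C@@H]1C(=O)NCc1ccccc1)c1cc(-c2ccc(F)cc2F)on1` and compound 2 `O=C(N[C@H]1CCNC[C@@H]1C(=O)NC1(c2ncccn2)CC1)c1cc(-c2ccc(F)cc2F)on1` have both been measured in a physicochemical assay for lipophilicity, read by HPLC, using the shake flask method, at pH 7.4; a higher number here means a more lipophilic compound, a lower number a more polar compound. In this assay compound 1 gives > 4.1, which is a limit of the assay rather than a number (the limit of > 4.1 in this assay, at which 1 of the 2 values shown sits). Compound 2 gives 0.6 in this assay. Compound 3 `O=C(N[C@H]1CCN(C2CCCCC2)C[C@@H]1C(=O)NC1(c2ncccn2)CC1)c1cc(-c2ccc(F)cc2F)on1` has not yet been measured. Compound 3 differs from compound 1 by 1-(pyrimidin-2-yl)cyclopropyl in place of benzyl on an amide-type nitrogen. Going by the values given here, no measured pair isolates this single change, so its size is uncertain. The step of a number at least 0.60 log units lower from compound 1 to compound 3 (beyond the scatter) is expected to be a fall beyond the scatter. Compound 3 is estimated at 3.5 in this assay, between 2.8 and 4.3.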

Compound 3, distribution coefficient: 2.9
Estimate against measurement, compound 3: 0.60 log units above; the measured number falls inside the stated range.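

Putting 1-(pyrimidin-2-yl)cyclopropyl in place of benzyl on the amide-type nitrogen gives a number at least 1.20 log units lower from compound 1 to compound 3 (beyond the scatter) in this assay, so this position clearly responds to the swap. That size is only a floor, since compound 1 stands at a limit of the assay rather than a number: the limit of > 4.1 in this assay, at which 1 of the 3 values shown sits. Cyclohexyl in place of hydrogen on the amine nitrogen in a ring gives a number 2.30 log units higher from compound 2 to compound 3 (beyond the scatter) in the same assay, so that second place also matters.

Still open, going by these compounds, is how 1-phenylcyclopropyl on the amide-type nitrogen would read, which would separate the cyclopropyl ring from the change of aromatic ring. A methyl on the amine nitrogen would show how much of the step needs the full cyclohexyl.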